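The compounds below may be only part of what the source reports. "The series", "measured", "known", "first", "only" and "open" are said of these compounds alone.

Measured so far in an ADME assay on L929 cells (Mus musculus) for cytotoxicity, read by resazurin assay, with a stated time of 72 h; on this read-out lower numbers stand for stronger inhibition and higher numbers for weaker inhibition:

compound 1 `CCc1ccc(C(=O)c2ccn(-c3ccc4c(c3)B(O)OC4)c2)cc1`: in this assay compound 1 gives > 10 ug/mL, which is a limit of the assay and not a number.
compound 2 `NCc1ccc(C(=O)c2ccn(-c3ccc4c(c3)B(O)OC4)c2)cc1`: in this assay compound 2 gives > 10 ug/mL, again a limit rather than a number.

Among the compounds with values here, compound 2 therefore stands only at a limit; no numerical position can be given for it, and the one further value shown is itself a limit. Within the data shown here, the single measured step, a step that the two limits leave unreadable from compound 1 to compound 2, cannot be read in size, since both of its values sit at the limit of > 10 ug/mL in this assay, at which 2 of the 2 values shown sit.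

Compound 3 `NCCCC(=O)c1ccn(-c2ccc3c(c2)B(O)OC3)c1` differs from compound 2 by 3-aminopropyl in place of 4-(aminomethyl)phenyl on a carbonyl carbon. Among the measured compounds shown here, no measured step bears on this kind of change, and the only step available is unreadable, so nothing in the data supports an expected shift in either direction beyond the scatter. The expected step is therefore a step that the limit leaves unreadable from compound 2 to compound 3, meaning no change that could be resolved. Compound 3 is estimated at 15 ug/mL, with a range from 5 ug/mL to 45 ug/mL, and the result is expected most likely to be reported again only as a limit.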

Compound 3, half-maximal inhibitory concentration: > 10 ug/mL
Compound 3 gave a limit, no number; the forecaster's own chance of this, stated with the estimate: 80%; the middle value is on the limit's open side.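

Within the data shown here, no step among compound 1, compound 2 and compound 3 can be read in this assay, since all three results are limits and not numbers: the limit of > 10 ug/mL in this assay, at which 3 of the 3 values shown sit. The compounds shown leave open whether replacing either 4-ethylphenyl or 4-(aminomethyl)phenyl with 3-aminopropyl on the carbonyl carbon changes the read-out at all, and what numerical value any of the three compounds has.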